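Methoxy in Place of Chloro: Expected Effect on Cell Inhibition

The source may report more compounds than this note shows. Statements on the series, on what has been measured and on what is new or still open speak of the compounds shown alone.

For the measured compounds named here, compound 2 `Clc1ccc(C2=NN(C3=NC(c4ccccc4)CS3)C(c3ccc4ccccc4c3)C2)cc1` gives 14600 nM in a functional assay on BGC-823 cells (Homo sapiens) for inhibition, read by CCK-8 assay, with a stated time of 48 h; on this read-out higher numbers stand for weaker inhibition and lower numbers for stronger inhibition; the only other number, from compound 1 `O=C1CSC(N2N=C(c3ccc(Cl)cc3)CC2c2ccc3ccccc3c2)=N1` at 13200 nM, lies within the scatter of it. Going by the values given here, the one measured step, a 1.1-fold higher number from compound 1 to compound 2 (0.04 log units; within the scatter), altered a different part of the shared core and stayed within the scatter. Compound 3 `COc1ccc(C2=NN(C3=NC(c4ccccc4)CS3)C(c3ccc4ccccc4c3)C2)cc1` carries methoxy in place of chloro on an aromatic carbon. Among the compounds with values here, no measured step touches this position, so the only guide is that the single recorded change moved the number little. Compound 3 is therefore expected to land near 14000 nM, within a range of 6000 nM to 35000 nM. This amounts to an expected 1.0-fold lower number from compound 2 to compound 3 (0.02 log units; within the scatter).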

Compound 3, half-maximal inhibitory concentration: 7250 nM
Compound 3: the middle estimate sits 1.9-fold (0.29 log units) above what was measured; measured number inside the range.
By their numbers in this assay, from the lowest: compounds 3, 1 and 2 (each within the scatter of the next).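

For the compounds shown here, this is the first measured change at this position: going from 4-chlorophenyl to 4-methoxyphenyl in this assay gives a 2.0-fold lower number from compound 2 to compound 3 (0.30 log units; within the scatter). So on this ring, the position accepts either chloro or methoxy with no difference that stands clear of the usual scatter. Nothing measured here bears on why the two groups read alike.

From the compounds shown here alone, whether an amine or a carboxylic acid at this position would shift the number beyond the scatter remains open. So does whether a longer chain in place of methoxy would do so.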